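Swapping a Diethylamino for a Methoxypropylamino Chain

The source may report more compounds than this note shows. Statements on the series, on what has been measured and on what is new or still open speak of the compounds shown alone.

Compound 1 `CCCCC(CC)Nc1nc(C)nc2c1nnn2-c1c(C)cc(C)cc1C`: 7.6 nM
Compound 2 `CCN(CC)c1nc(C)nc2c1nnn2-c1ccc(C(C)C)cc1Br`: 25.3 nM

Both values come from an in vitro assay on 293-EBNA cells for binding affinity to corticotropin-releasing factor receptor 1 (Homo sapiens); on this read-out lower numbers stand for stronger inhibition and higher numbers for weaker inhibition. Of the two numbers, compound 2 holds the higher one; compound 1 sits below it by a margin beyond the usual scatter. Compound 3 `COCCCNc1nc(C)nc2c1nnn2-c1ccc(C(C)C)cc1Br` differs from compound 2 in a single place: (3-methoxypropyl)amino in place of diethylamino on an aromatic carbon. Among the measured compounds shown here, no measured pair shows this exact change, so the direction and size of the step rest on judgement alone. The expected step of a 1.6-fold higher number from compound 2 to compound 3 (0.20 log units; within the scatter) is modest and upward, and may not reach beyond the scatter. Compound 3 is estimated at 40 nM, with a range from 10 nM to 160 nM.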

Compound 3, inhibition constant: 291 nM
The estimate for compound 3 lay 7.3-fold (0.86 log units) below the measured number; the measured number lies above the stated range.
By their numbers in this assay, from the lowest: compound 1; then compound 2; then compound 3.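

In this assay, the aromatic carbon next to the ring nitrogen proves sensitive to what it carries: (3-methoxypropyl)amino in place of diethylamino gives a 12-fold higher number from compound 2 to compound 3 (1.06 log units; beyond the scatter), a large loss of inhibition. The entering chain differs in more than one way, adding both an oxygen and a hydrogen-bond donor, and this single step cannot separate the two. Nothing available accounts for the loss.

Still open, on these data alone, is whether a plain butylamino chain, without the oxygen, would behave like the (3-methoxypropyl)amino chain. Also open, as far as these compounds go, is whether an ethyl group on that chain's nitrogen, replacing its hydrogen, would bring the number back toward that of compound 2.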